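A few compounds are considered here, and "the series" means these few. Any claim that something is new, unique, unknown or untested is made for them only; others in the source may bear on it.

Going by the values given here, compound 2 `CC(C)=CCOc1cc(Nc2ccccn2)ccc1C` stands highest of the two numbers so far: in a functional assay on MT2 cells (Homo sapiens) for cytotoxicity, read by MTT assay (a higher number here means that more compound is tolerated, a lower number that less compound is tolerated), compound 2 gives 35000 nM, while compound 1 `CC(C)=CCOc1cc(Nc2nccs2)ccc1C` gives 17000 nM. Among the compounds with values here, the only measured step is a 2.1-fold higher number from compound 1 to compound 2 (0.31 log units; beyond the scatter), which also changed the ring on a nitrogen on an aromatic ring. Compound 3 `CC(C)=CCOc1cc(Nc2ncccn2)ccc1C` differs from compound 2 by pyrimidin-2-yl in place of pyridin-2-yl on a nitrogen on an aromatic ring. Within the data shown here, no measured step exchanges pyridin-2-yl for pyrimidin-2-yl, and the one step available was modest, so for compound 3 a step within the scatter is expected, a 1.1-fold higher number from compound 2 to compound 3 (0.06 log units; within the scatter). Compound 3 is therefore estimated at 40000 nM, with a range of 17000 nM to 90000 nM.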

Compound 3, half-maximal cytotoxic concentration: 78000 nM
Estimate against measurement, compound 3: 2.0-fold (0.29 log units) below; low and high end bracket the measured number.
By their numbers in this assay, from the lowest: compound 1; then compound 2; then compound 3.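

Exchanging pyridin-2-yl for pyrimidin-2-yl on a nitrogen on an aromatic ring is not a neutral change in this assay, since it gives a 2.2-fold higher number from compound 2 to compound 3 (0.35 log units; beyond the scatter), so a ring with 2 hetero atoms is tolerated at a higher concentration here than one with 1. Going by these compounds alone, with a 4.6-fold higher number from compound 1 to compound 3 (0.66 log units; beyond the scatter) as the widest step so far, pyrimidin-2-yl stands as the most tolerated of the three rings at this place. Nothing available accounts for this order. On these data alone, whether a plain phenyl ring or a saturated piperidine at this place would continue the order stays open, as does whether the order would hold with a longer chain in place of the one on the oxygen.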